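From Methoxy to Nitrile: Expecting Little Change

The compounds below may be only part of what the source reports. "The series", "measured", "known", "first", "only" and "open" are said of these compounds alone.

Of the compounds shown here, three have been measured in an in vitro functional assay on HEK293 cells for antagonist activity at melanin-concentrating hormone receptor 1 (Homo sapiens), read by GTPgammaS binding, with a stated time of 45 min; a higher number here means a weaker inhibitor, a lower number a stronger inhibitor. Compound 1 `Cc1ccc(CN2CCC(NC(=O)NCc3ccc(-c4ccccc4)cc3)CC2)cc1` gives 1060 nM. Compound 2 `Cc1ccc(CN2CCC(CCN(Cc3ccc(-c4ccc(F)cc4)cc3)C(=O)NC(C)C)CC2)cc1` gives 383 nM, and compound 3 `COc1ccc(-c2ccc(CN(CCC3CCN(Cc4ccc(C)cc4)CC3)C(=O)NC(C)C)cc2)cc1` gives 467 nM. On these numbers compound 3 holds the second highest place: its nearest neighbour is compound 2, whose number is lower by an amount within the scatter, while compound 1 lies furthest away, with a number higher by an amount beyond the scatter.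

Compound 4 `Cc1ccc(CN2CCC(CCN(Cc3ccc(-c4cccc(C#N)c4)cc3)C(=O)NC(C)C)CC2)cc1` has not yet been measured. It differs from compound 3 in one place: 3-cyanophenyl in place of 4-methoxyphenyl on an aromatic carbon. Among the measured compounds shown here, only one measured step bears on this change, and that is the exchange of groups on the same outer ring that gave a 1.2-fold higher number from compound 2 to compound 3 (0.09 log units; within the scatter). That step stayed within the scatter, so exchanging one small group for another on this outer ring has so far left the number essentially where it was. For the measured compounds named here, the present change puts a 3-cyanophenyl where a 4-methoxyphenyl stood, which is a different kind of exchange, so the one known step is only a loose guide. The expectation for this assay is therefore a step of about a 1.0-fold lower number from compound 3 to compound 4 (0.02 log units; within the scatter), with no clear direction beyond the scatter. Compound 4 is expected to give 450 nM, within a range from 150 nM to 1400 nM.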

Compound 4, antagonist equilibrium constant: 1010 nM
Beside the measured number, compound 4's estimate is 2.2-fold (0.35 log units) below it; low and high end bracket the measured number.
By their numbers in this assay, from the lowest: compounds 2 and 3 (each within the scatter of the next); then compounds 4 and 1 (each within the scatter of the next).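

In this assay, among the compounds shown here, the outer ring proves less tolerant of exchange than the earlier compounds suggested: the change to 3-cyanophenyl gives a 2.2-fold higher number from compound 3 to compound 4 (0.34 log units; beyond the scatter), a modest weakening that lies beyond the scatter, whereas the earlier exchange of fluoro for methoxy, a 1.2-fold higher number from compound 2 to compound 3 (0.09 log units; within the scatter), stayed within it. Measured against the fluoro compound, the same ring gives a 2.6-fold higher number from compound 2 to compound 4 (0.42 log units; beyond the scatter), so 3-cyanophenyl stands apart from both 4-methoxyphenyl and 4-fluorophenyl, even though 4-methoxyphenyl and 3-cyanophenyl have the same counts of heavy atoms and hydrogen-bond acceptors, which therefore do not separate these two groups. Nothing available here gives a reason for this shift.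

Going by these compounds, what stays open is whether the higher number goes with the nitrile itself or with where it sits, as the group and its place on the ring change together in this step, and a 4-cyanophenyl or a 3-methoxyphenyl would pull those two apart. Also open, on these data alone, is how a ring carrying an amine or a carboxylic acid would read in this assay.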